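Acetyl for fluoro at the pendant phenyl ring

This account rests on a few compounds, and the source may have more. Where it says the series, first, only, none or still open, it means among the compounds named here.

Measured so far:
compound 1 `COc1ccc(-c2cn3ccnc3c(-c3ccc4ncn(C5CCCCC5)c4c3)n2)cc1`, -18.6%
compound 2 `Fc1ccc(-c2cn3ccnc3c(-c3ccc4ncn(C5CCCCC5)c4c3)n2)cc1`, 1.78%

In a functional assay on MDA-MB-435 cells (Homo sapiens) for inhibition, read by sulforhodamine B assay, with a stated time of 48 h, tested at 10 uM (a lower number here means less inhibition, a higher number more inhibition at the concentration tested (going by the name of the read-out)), compound 2 stands highest of the two numbers, with compound 1 the nearest at the lower value. Among the compounds with values here, the single step recorded, a number 20.4 percentage points higher from compound 1 to compound 2 (beyond the scatter), is the only measured change on this phenyl ring and concerns a different pair of groups. Compound 3 `CC(=O)c1ccc(-c2cn3ccnc3c(-c3ccc4ncn(C5CCCCC5)c4c3)n2)cc1` is not yet measured; it differs from compound 2 by acetyl in place of fluoro on an aromatic carbon, on an aromatic carbon para to a large group. Within the data shown here, no measured step involves acetyl, so the prior step gives only a sense of the scale that a single substituent swap at this position can produce, not its direction. The estimated step of a number 3.2 percentage points higher from compound 2 to compound 3 (within the scatter) is therefore small and uncertain. Compound 3 is expected to give about 5% in this assay, within -15% to 30%.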

Compound 3, a percentage reported as inhibition, at one concentration (the size of the read-out at that concentration, not a potency): 6%
Estimate against measurement, compound 3: 1 percentage points below; measured number inside the range.
By their numbers in this assay, from the lowest: compound 1; then compounds 2 and 3 (each within the scatter of the next).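

In this assay, acetyl in place of fluoro gives a number 4.2 percentage points higher from compound 2 to compound 3 (within the scatter), so the hydrogen-bond acceptor and the extra heavy atoms that enter with acetyl come with no step beyond the scatter. Acetyl in place of methoxy gives a number 24.6 percentage points higher from compound 1 to compound 3 (beyond the scatter), which, with the earlier fluoro step, leaves methoxy as the one group of the three that stands apart at this position, while fluoro and acetyl cannot be told apart at this concentration. Nothing given here accounts for the separation of methoxy from the other two groups.

Going by these compounds, whether an amine, a carboxylic acid or a longer chain on this aromatic carbon would move the number beyond the scatter from compound 2 remains open. The rest of the structure is the same in all three compounds, so changes elsewhere on the shared core cannot be judged from them.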